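Hydroxy for methoxy: one readable number among three

The source may hold more compounds than are shown below. What is called first, only, known or untested is meant among the compounds shown, and "the series" means these compounds.

Measured compounds:
Compound 1 `COc1cc(-c2nn(-c3cccc(NC(=O)Nc4cc(C(F)(F)F)cc(C(F)(F)F)c4)c3)cc2-c2ccncc2)ccc1Cl` — 10900 nM
Compound 2 `COc1cc(-c2nn(-c3cccc(NC(=O)Nc4ccc(Cl)c(Cl)c4)c3)cc2-c2ccncc2)ccc1Cl` — > 50000 nM, a limit of the assay
Compound 3 `O=C(Nc1cccc(-n2cc(-c3ccncc3)c(-c3ccc(Cl)c(O)c3)n2)c1)Nc1ccc(Cl)c(Cl)c1` — > 32500 nM, a limit of the assay

Within the data shown here, in a functional assay on MCF7 cells (Homo sapiens) for inhibition, read by sulforhodamine B assay, with a stated time of 48 h (on this read-out higher numbers stand for weaker inhibition of growth and lower numbers for stronger inhibition of growth), compound 1 gives 10900 nM, the only number among the three measured compounds. For compound 2 the reported value > 50000 nM is a limit of the assay. For compound 3 the reported value > 32500 nM is likewise a limit. The step that the two limits leave unreadable from compound 2 to compound 3, (hydrogen in place of methyl on an oxygen on an aromatic ring), thus has no readable size, since one value sits at the limit of > 50000 nM in this assay, at which 1 of the 3 values shown sits, and the other at the limit of > 32500 nM in this assay, at which 1 of the 3 values shown sits. How the core of compound 1 differs from that of compound 2 is not broken down here.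

Compound 4 `O=C(Nc1cccc(-n2cc(-c3ccncc3)c(-c3ccc(Cl)c(O)c3)n2)c1)Nc1cc(C(F)(F)F)cc(C(F)(F)F)c1` differs from compound 1 by the same change, (hydrogen in place of methyl on an oxygen on an aromatic ring). With the measured instance of this change unreadable, the expectation for compound 4 rests on compound 1 alone, and a step of a 1.1-fold higher number from compound 1 to compound 4 (0.04 log units; within the scatter) is estimated. Compound 4 is therefore expected to give about 12000 nM, between 3000 nM and 50000 nM.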

Compound 4, concentration for total growth inhibition: 5790 nM
Compound 4: the middle estimate sits 2.1-fold (0.32 log units) above what was measured; measured number inside the range.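

In this assay, the change from methoxy to hydroxy on the core of compound 1 is a 1.9-fold lower number from compound 1 to compound 4 (0.27 log units; within the scatter) and so leaves the two compounds indistinguishable on this core. The same change from compound 2 to compound 3 cannot be read, as both reported values are limits of the assay, so this single readable instance does not show that the change carries from one core to another. Nothing reported here accounts for the result.

The compounds shown leave open how an amine or a carboxylic acid in place of the hydroxy would read on the core of compound 1. Going by these compounds, a longer chain on the oxygen, such as ethoxy, also remains open.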